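The compounds below may be only part of what the source reports. "The series", "measured", "known", "first", "only" and "open" are said of these compounds alone.

Measured so far in an ADME assay on microsomes from liver (Homo sapiens) for metabolic stability; a higher number here means that the compound lasts longer, a lower number that the compound disappears faster:
Compound 1, `C[C@H](CSc1nonc1/C(=N/O)Nc1ccc(F)c(Br)c1)NC(=O)CS(N)(=O)=O`, gives 0.77 h.
Compound 2, `N#Cc1cccc(N/C(=N\O)c2nonc2SCCNC(=O)CS(N)(=O)=O)c1`, gives > 3 h.
Compound 3, `CS(=O)(=O)NCCSc1nonc1/C(=N/O)Nc1ccc(F)c(Br)c1`, gives 1.73 h.

Compound 2 stands apart from the other two: its result is a limit of the assay, not a number, as the limit of > 3 h in this assay, at which 1 of the 3 values shown sits, shows, so the true half-life of compound 2 is only known to lie beyond that point. Compound 4, `NS(=O)(=O)CC(=O)NCCSc1nonc1/C(=N/O)Nc1ccc(F)c(Br)c1`, is not yet measured. It differs from compound 2 in one place: 3-bromo-4-fluorophenyl in place of 3-cyanophenyl on an amine nitrogen. Compound 1 and compound 3 carry the same 3-bromo-4-fluorophenyl group and both returned plain numbers in this assay rather than a limit. Compound 4 is therefore expected to fall below the limit, and the step of an at least 2.0-fold lower number from compound 2 to compound 4 (0.30 log units; that floor lies within the scatter) is estimated to be downward, though how far cannot be told from a limit. The estimate for compound 4 is 1.5 h, with a range from 0.7 h to 3.5 h.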

Compound 4, half-life: 2.37 h
The estimate for compound 4 lay 1.6-fold (0.20 log units) below the measured number; the range from low to high includes it.
By their numbers in this assay, from the lowest: compound 1; then compounds 3 and 4 (each within the scatter of the next). At a limit, above all of these: compound 2.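

In this assay, 3-bromo-4-fluorophenyl in place of 3-cyanophenyl on the amine nitrogen gives an at least 1.2-fold lower number from compound 2 to compound 4 (0.10 log units; that floor lies within the scatter), so this change is not shown to matter beyond the scatter. Its true size stays unknown, because the result for compound 2 is a limit of the assay and not a number: the limit of > 3 h in this assay, at which 1 of the 4 values shown sits.

With 3-bromo-4-fluorophenyl held fixed, hydrogen in place of methyl on the chain gives a 3.1-fold higher number from compound 1 to compound 4 (0.49 log units; beyond the scatter), whereas (sulfamoylmethyl)carbonyl in place of methylsulfonyl gives a 1.4-fold higher number from compound 3 to compound 4 (0.14 log units; within the scatter).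

As far as these compounds go, whether the methyl step would carry over to compounds with 3-cyanophenyl remains open. So does how an unsubstituted phenyl on the amine nitrogen, or an ethyl in place of the methyl on the chain, would behave in this assay.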